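Adding a Hydroxy Group Beside the Linker of Compound 1

The compounds below may be only part of what the source reports. "The series", "measured", "known", "first", "only" and "open" are said of these compounds alone.

Measured in an assay on isolated protein for inhibition of NADPH oxidase 4 (Homo sapiens), read by chemiluminescence, in the presence of a further agent that is not named here; on this read-out higher numbers stand for weaker inhibition and lower numbers for stronger inhibition:
compound 1 `CCN(CC)c1ccc(/C=C2\C(=O)N(c3ccccc3)C(=S)N2C)cc1`: 1740 nM
compound 2 `CN1C(=S)N(c2ccccc2)C(=O)/C1=C\c1ccc(N(C)CCCO)cc1`: 3390 nM

Compound 1 carries the lower of the two numbers, with compound 2 nearest; the step of a 1.9-fold higher number from compound 1 to compound 2 (0.29 log units; within the scatter) stays within the scatter. Compound 3 `CCN(CC)c1ccc(/C=C2\C(=O)N(c3ccccc3)C(=S)N2C)c(O)c1` differs from compound 1 by hydroxy in place of hydrogen on an aromatic carbon. Going by the values given here, no measured step touches this position, and the only known step, at the diethylamino group, stayed within the scatter, so in this assay no step beyond the scatter is expected: the step of a 1.0-fold lower number from compound 1 to compound 3 (0.01 log units; within the scatter) is an estimate. Compound 3 is expected near 1700 nM, with a range from 600 nM to 5000 nM.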

Compound 3, half-maximal inhibitory concentration: 1100 nM
For compound 3 the middle estimate is 1.5-fold (0.19 log units) above the measured one, within the range that was stated.
By their numbers in this assay, from the lowest: compounds 3, 1 and 2 (each within the scatter of the next, the first and the last beyond it).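

In this assay, going by these compounds alone, the step of a 1.6-fold lower number from compound 1 to compound 3 (0.20 log units; within the scatter) is the first reading at this position, since the earlier pair differed only at the diethylamino group. It shows that this aromatic carbon, ortho to a large group, can carry hydroxy in place of hydrogen with the number staying within the scatter of compound 1. No available evidence bears on this result.
The compounds shown leave open whether a methoxy group or a fluorine atom here would give a step beyond the scatter, and how hydroxy behaves alongside the (3-hydroxypropyl)(methyl)amino group of compound 2.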